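This account rests on a few compounds, and the source may have more. Where it says the series, first, only, none or still open, it means among the compounds named here.

In an ADME assay on microsomes from liver (Canis lupus familiaris) for metabolic stability (on this read-out higher numbers stand for a longer-lived compound and lower numbers for a shorter-lived compound), the measured compounds read as follows, and each value is a limit, not a number:

- compound 1 `Nc1nc(NCCNc2ncc(-c3ncc[nH]3)c(-c3ccc(Cl)cc3)n2)ccc1[N+](=O)[O-]` gives > 0.5 h
- compound 2 `Nc1nc(NCCNc2ncc(-c3ncc[nH]3)c(-c3ccccc3Br)n2)ccc1[N+](=O)[O-]` gives > 0.5 h
- compound 3 `Nc1nc(NCCNc2ncc(-c3ncc[nH]3)c(-c3ccc(Br)cc3F)n2)ccc1[N+](=O)[O-]` gives > 0.5 h

Compound 3 stands at > 0.5 h and this is a limit, not a true reading. Compound 4 `Cc1cc(Cl)ccc1-c1nc(NCCNc2ccc([N+](=O)[O-])c(N)n2)ncc1-c1ncc[nH]1` differs from compound 3 in one place, with 4-chloro-2-methylphenyl in place of 4-bromo-2-fluorophenyl on an aromatic carbon. The closest evidence comes from two steps that also change this group, and neither gives a size: one is a step that the two limits leave unreadable from compound 1 to compound 3 and the other is a step that the two limits leave unreadable from compound 2 to compound 3 in the same assay. The remaining pair offers no more, as it shows a step that the two limits leave unreadable from compound 1 to compound 2 too. The whole set amounts to the limit of > 0.5 h in this assay, at which 3 of the 3 values shown sit, and it points in no direction. No step beyond the usual scatter is therefore expected in this assay, and the expected change is small (a step that the limit leaves unreadable from compound 3 to compound 4). For compound 4 the estimate is 0.6 h with an expected range from 0.35 h to 1 h and a report of only a limit is also expected to be likely.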

Compound 4, half-life: > 0.5 h
Compound 4 ended at the assay's limit; the forecaster's own chance of this, stated with the estimate: 75%; the middle value lies beyond the limit too.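

In this assay compound 4 gives > 0.5 h, which is a limit and not a number, so its steps from compound 1, compound 2 and compound 3 cannot be read. The compounds shown leave open how long each one truly lasts and whether changing this aromatic group alters that at all.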